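The compounds below may be only part of what the source reports. "The series", "measured", "known", "first", "only" and "open" are said of these compounds alone.

Measured in a functional assay on PC-3 cells (Homo sapiens) for antiproliferative activity, read by MTT assay, with a stated time of 24 h; on this read-out higher numbers stand for weaker inhibition and lower numbers for stronger inhibition:
- compound 1 `CCn1c(C(=O)NCC(=O)OC)ccc1C(CC)(CC)c1ccc(OCS(=O)(=O)c2ccccc2)c(C)c1`: > 50000 nM (a limit of the assay)
- compound 2 `CCn1c(C(=O)NC(C)(C)CO)ccc1C(CC)(CC)c1ccc(OCS(=O)(=O)c2ccccc2)c(C)c1`: 9850 nM
- compound 3 `CCn1c(C(=O)N[C@@H](C(=O)O)C(C)C)ccc1C(CC)(CC)c1ccc(OCS(=O)(=O)c2ccccc2)c(C)c1`: 3070 nM

Compound 3, at 3070 nM, has the lower of the two actual numbers in this assay. For the measured compounds named here, the only other actual number belongs to compound 2, and the gap is beyond the scatter: a 3.2-fold lower number from compound 2 to compound 3 (0.51 log units; beyond the scatter).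

Compound 4 `CCn1c(C(=O)N[C@@H](CC(=O)O)C(=O)O)ccc1C(CC)(CC)c1ccc(OCS(=O)(=O)c2ccccc2)c(C)c1` is not yet measured. Its change from compound 3 is 1,2-dicarboxyethyl in place of 1-carboxy-2-methylpropyl on an amide-type nitrogen. In short, 1,2-dicarboxyethyl stands in place of 1-carboxy-2-methylpropyl on an amide-type nitrogen.

Two measured steps act at this same place. One is large, an at least 16-fold lower number from compound 1 to compound 3 (1.21 log units; beyond the scatter), and the other is modest, a 3.2-fold lower number from compound 2 to compound 3 (0.51 log units; beyond the scatter). Neither brings in 1,2-dicarboxyethyl, so they bear on the new change only indirectly. The entering group keeps a carboxy group, as in compound 3, which points to a value near that of compound 3 at 3070 nM. The size of the step to compound 3 from compound 1, an at least 16-fold lower number from compound 1 to compound 3 (1.21 log units; beyond the scatter), shows that this place can move the number considerably, so the range is kept wide and leans towards higher numbers.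

The expected change is a 1.5-fold higher number from compound 3 to compound 4 (0.17 log units; within the scatter), probably not beyond the scatter. The estimate for compound 4 is 4500 nM, with an expected range of 1500 nM to 20000 nM.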

Compound 4, half-maximal inhibitory concentration: > 50000 nM
Compound 4: only a limit was reported; the forecaster's own chance of this, stated with the estimate: 15%; at least 11-fold (1.04 log units) between middle value and limit.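

In this assay, keeping a carboxy group on the amide-type nitrogen does not by itself preserve the number: 1,2-dicarboxyethyl in place of 1-carboxy-2-methylpropyl gives an at least 16-fold higher number from compound 3 to compound 4 (1.21 log units; beyond the scatter). The 1-(hydroxymethyl)-1-methylethyl group, which has no carboxy group, also gives the lower number, with an at least 5.0-fold higher number from compound 2 to compound 4 (0.70 log units; beyond the scatter), so the presence of a carboxy group does not set the order at this position among the compounds shown. Compound 4 stands at a limit of the assay, as does compound 1, and the step between these two cannot be read: the limit of > 50000 nM in this assay, at which 2 of the 4 values shown sit.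

The compounds shown do not separate the effect of adding the second carboxy group from that of removing the branched carbon end of 1-carboxy-2-methylpropyl, as the step to 1,2-dicarboxyethyl changes both at once. A primary amide in place of the second carboxy group, or a longer chain carrying that carboxy group, would test whether the large step depends on the second acid itself or on its distance from the amide-type nitrogen.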